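The source may hold more compounds than are shown below. What is called first, only, known or untested is meant among the compounds shown, and "the series" means these compounds.

Measured in a functional assay on CCRF-CEM cells (Homo sapiens) for cytotoxicity; a higher number here means that more compound is tolerated, a lower number that less compound is tolerated:
- compound 1 `Cc1cccc2c1OP(=O)(OCC1CCC(n3cnc4c(O)ncnc43)O1)OC2` gives 58000 nM
- compound 2 `COc1ccc2c(c1)COP(=O)(OC[C@@H]1C=C[C@H](n3cnc4c(N)ncnc43)O1)O2` gives 62000 nM; 40000 nM; 77000 nM (3 entries)

Compound 1 has a single number, 58000 nM in this series, and one further entry that gives no single number. Its standing therefore rests on thin data. The value of compound 1 at 58000 nM lies inside the spread of the repeat entries for compound 2 (the several entries of compound 2 in this assay, 62000 nM; 40000 nM; 77000 nM (3 entries)), so the two cannot be ranked. They also differ in more than one place, so this pair says nothing about a single change.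

Compound 3 `Cc1cccc2c1OP(=O)(OCC1CC(O)C(n3cnc4c(O)ncnc43)O1)OC2` keeps the core of compound 1 and carries hydroxy in place of hydrogen on a saturated ring carbon, as counted in hydroxy in place of hydrogen on a saturated ring carbon for this pair. Going by the values given here, no measured pair tests this change, so the expectation starts from compound 1 at 58000 nM and assumes no shift beyond the scatter. The expected 1.2-fold higher number from compound 1 to compound 3 (0.08 log units; within the scatter) is therefore small, with no firm direction.

In this assay compound 3 is estimated at 70000 nM and expected to fall between 28000 nM and 170000 nM on repeat measurement.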

Compound 3, half-maximal cytotoxic concentration: 94000 nM
The estimate for compound 3 lay 1.3-fold (0.13 log units) below the measured number; the range from low to high includes it.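

In this assay, compound 1 and compound 3 form the only pair shown that differs in one place, so this pair gives the series its first direct reading of a single change: hydroxy in place of hydrogen on a saturated ring carbon, with a 1.6-fold higher number from compound 1 to compound 3 (0.21 log units; within the scatter). On this one pair, hydroxy at this place, on the five-membered non-aromatic ring with 1 oxygen and two ring bonds from the ring oxygen, gives no separation from hydrogen that exceeds the scatter, so the two compounds cannot be ranked and the step supports no claim of a real difference in either direction. A single compound can spread about as widely on repeat measurement as this step, so the step should not be read as a trend: the several entries of compound 2 in this assay, 62000 nM; 40000 nM; 77000 nM (3 entries)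

Going by these compounds, whether a group other than hydroxy at this same ring carbon, such as an amine, a methoxy or a carboxylic acid, would separate from hydrogen beyond the scatter remains open. The compounds shown also leave open whether the same hydroxy for hydrogen change would give a similar result on the core of compound 2, as a single pair on the core of compound 1 cannot show this.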